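The compounds below may be only part of what the source reports. "The series", "measured", "known", "first", "only" and "open" are said of these compounds alone.

In a functional assay on MT4 cells (Homo sapiens) for inhibition (a lower number here means a stronger inhibitor, a higher number a weaker inhibitor), three compounds have been measured. Compound 1 `C/C(=C\COc1c(Cl)cccc1Cl)CC/C=C(\C)C1CC(=O)C(C)(C)O1` gives 32.5 ug/mL, compound 2 `C/C(=C\COc1ccccc1)CC/C=C(\C)C1CC(=O)C(C)(C)O1` gives 43.1 ug/mL, and compound 3 `C/C(=C\COc1c(Cl)cccc1Cl)CC/C=C(\C)C1=CC(=O)C(C)(C)O1` gives 15.5 ug/mL. Compound 3 thus holds the lowest of the three numbers, and it lies beyond the scatter from both of the others.

Among the measured compounds shown here, the next compound, compound 4 `COc1ccc(OC/C=C(\C)CC/C=C(\C)C2=CC(=O)C(C)(C)O2)cc1`, keeps the core of compound 3 and alters only one group: 4-methoxyphenyl in place of 2,6-dichlorophenyl on an oxygen on a saturated carbon. It carries 4-methoxyphenyl in place of 2,6-dichlorophenyl on an oxygen on a saturated carbon.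

The closest evidence is a 1.3-fold higher number from compound 1 to compound 2 (0.12 log units; within the scatter). That step also removes 2,6-dichlorophenyl from an oxygen on a saturated carbon, but it puts phenyl there and belongs to the core of compound 1. It stays within the scatter. The other measured step, a 2.1-fold lower number from compound 1 to compound 3 (0.32 log units; beyond the scatter), is modest and changes the core rather than this group, so it bears on the starting level only. For the measured compounds named here, no measured compound carries 4-methoxyphenyl, so the evidence is indirect. A step no larger than the scatter is therefore expected in this assay, leaning slightly towards a higher number.

The estimated change is a 1.3-fold higher number from compound 3 to compound 4 (0.11 log units; within the scatter). For compound 4 the expected value is 20 ug/mL, within an estimated range from 9 ug/mL to 42 ug/mL.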

Compound 4, half-maximal inhibitory concentration: 33.9 ug/mL
Estimate against measurement, compound 4: 1.7-fold (0.23 log units) below, within the range that was stated.
By their numbers in this assay, from the lowest: compound 3; then compounds 1, 4 and 2 (each within the scatter of the next).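

In this assay the group on an oxygen on a saturated carbon proves able to move the number, as the core of compound 3 shows a modest step of a 2.2-fold higher number from compound 3 to compound 4 (0.34 log units; beyond the scatter) when 4-methoxyphenyl replaces 2,6-dichlorophenyl. Among the compounds shown here, the only earlier change at this place, with phenyl replacing 2,6-dichlorophenyl on the core of compound 1, gave a 1.3-fold higher number from compound 1 to compound 2 (0.12 log units; within the scatter) and so stayed within the scatter, whereas the new step lies beyond it and moves towards a weaker inhibitor. Nothing available here accounts for this difference between the two steps, which differ in both the entering group and the core.

The compounds shown leave open whether the new step follows from the loss of 2,6-dichlorophenyl or the arrival of 4-methoxyphenyl, and whether the same exchange would give a step of similar size on the core of compound 1. They also leave open how the number would respond to an amine or a carboxylic acid on the aromatic ring at this place.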